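The source may hold more compounds than are shown below. What is called first, only, known or untested is meant among the compounds shown, and "the series" means these compounds.

In a functional assay on MCF7 cells (Homo sapiens) for antiproliferative activity, read by MTT assay, with a stated time of 48 h (on this read-out higher numbers stand for weaker inhibition and lower numbers for stronger inhibition), compound 3 `Cc1ccc(-c2nnc(NC(=O)/C=C/c3ccccc3)s2)cc1` gives 1.19 ug/mL. This sits within the scatter of compound 1 `O=C(/C=C/c1ccccc1)Nc1nnc(-c2ccccc2)s1` at 1.47 ug/mL and of compound 2 `O=C(/C=C/c1ccc(F)cc1)Nc1nnc(-c2ccc(Br)cc2)s1` at 1.49 ug/mL, so the three measured numbers do not separate from one another.

The next structure is compound 4 `O=C(/C=C/c1ccccc1)Nc1nnc(-c2ccc(Br)cc2)s1`, which carries bromo in place of methyl on an aromatic carbon. Within the data shown here, only one measured step bears directly on this position: a 1.2-fold lower number from compound 1 to compound 3 (0.09 log units; within the scatter), where methyl replaces hydrogen on an aromatic carbon. That step stays within the scatter. Compound 2 at 1.49 ug/mL already has the 4-bromophenyl group of compound 4, although it differs from compound 4 elsewhere, and its number remains within the scatter of the other two. Among the measured compounds shown here, no measured pair isolates the exchange of methyl for bromo, so this expectation rests on indirect evidence.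

No shift beyond the scatter is expected in this assay. The estimated change is a 1.2-fold higher number from compound 3 to compound 4 (0.07 log units; within the scatter), which would be too small to read as a real difference. The expected value for compound 4 is 1.4 ug/mL, with an estimated range of 0.9 ug/mL to 2.2 ug/mL.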

Compound 4, half-maximal inhibitory concentration: 1.5 ug/mL
The estimate for compound 4 lay 1.1-fold (0.03 log units) below the measured number, within the range that was stated.
By their numbers in this assay, from the lowest: compounds 3, 1, 2 and 4 (each within the scatter of the next).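

In this assay, the exchange of 4-methylphenyl for 4-bromophenyl now has a direct reading, a 1.3-fold higher number from compound 3 to compound 4 (0.10 log units; within the scatter), so this change no longer rests on indirect comparison. With bromo in place of hydrogen on the same aromatic carbon, the reading is a 1.0-fold higher number from compound 1 to compound 4 (0.01 log units; within the scatter), and together with the earlier methyl step this means hydrogen, methyl and bromo at this position do not separate from one another in these numbers. A second place on the molecule also has its first single-change reading, with hydrogen in place of fluoro on an aromatic carbon giving a 1.0-fold higher number from compound 2 to compound 4 (0.00 log units; within the scatter), so fluoro at that place does not separate from hydrogen on the 4-bromophenyl background.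

No available evidence accounts for these readings. Still open, going by these compounds, is whether an amine, a carboxylic acid or a longer chain in place of bromo at this position, or a methoxy group in place of fluoro at the second place, would give a number that moves beyond the scatter.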